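The source may hold more compounds than are shown below. What is called first, only, known or untested is meant among the compounds shown, and "the series" means these compounds.

Measured so far in an ADME assay for permeability, using PAMPA, at pH 7.4; a lower number here means that the compound crosses the layer more slowly, a higher number that the compound crosses the layer faster:
compound 1 `Cc1[nH]c2ccccc2c(=O)c1Cc1ccccc1`: 102 10^-6 cm/s
compound 2 `Cc1[nH]c2ccc(Cl)cc2c(=O)c1Cc1ccccc1`: 415 10^-6 cm/s
compound 3 `Cc1[nH]c2cccc(Cl)c2c(=O)c1Cc1ccccc1`: 251 10^-6 cm/s

Compound 2 and compound 3 lie within the scatter of each other, so no order is claimed between them. Compound 1 sits lower than both. The series shows a 4.1-fold higher number from compound 1 to compound 2 (0.61 log units; beyond the scatter) and a 2.5-fold higher number from compound 1 to compound 3 (0.39 log units; beyond the scatter), each modest and beyond the scatter.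

Next in view is compound 4 `Cc1c(Cc2ccccc2)c(=O)c2cc(Cl)ccc2n1C`, which keeps the chloro group of compound 2 and carries one change: methyl in place of hydrogen on an aromatic nitrogen. Going by the values given here, no measured step covers this kind of replacement. Among the compounds with values here, the two chloro steps are the only steps available, and they bear on it only loosely, as a guide to how far a single small replacement has moved the number on this core so far. They give no direction for a methyl group on nitrogen.

With so little to go on, no step beyond the scatter is expected in this assay, with only a slight lean towards a higher number. The expected change is a 1.2-fold higher number from compound 2 to compound 4 (0.06 log units; within the scatter). For compound 4 the estimated value is 480 10^-6 cm/s, with an expected range of 210 10^-6 cm/s to 1000 10^-6 cm/s.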

Compound 4, apparent permeability: 489 10^-6 cm/s
Compound 4: middle estimate off by 1.0-fold (0.01 log units), on the low side, and the stated range covers the measured number.
By their numbers in this assay, from the lowest: compound 1; then compounds 3, 2 and 4 (each within the scatter of the next).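

In this assay, going by these compounds alone, the first change at the aromatic nitrogen, methyl in place of hydrogen on the chloro-bearing compound, gives a 1.2-fold higher number from compound 2 to compound 4 (0.07 log units; within the scatter), so the hydrogen on this nitrogen is not needed to keep the number at the level seen for compound 2. The earlier steps shown here, both chloro in place of hydrogen on an aromatic carbon, were a 4.1-fold higher number from compound 1 to compound 2 (0.61 log units; beyond the scatter) and a 2.5-fold higher number from compound 1 to compound 3 (0.39 log units; beyond the scatter), each beyond the scatter, whereas this replacement on nitrogen cannot be told apart from repeat measurement, and the series now holds a single-atom change that leaves the read-out where it was. Nothing measured here speaks to what lies behind this result.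

Within the data shown here, whether methyl on this nitrogen reads the same on the core of compound 1, without the chloro group, stays open, since the one step shown sits on the chloro-bearing compound alone. Also open, on these data alone, is how this assay responds when this nitrogen carries something other than methyl, such as a longer chain, an amine or a carboxylic acid.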